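Sulfamoyl for Nitro: Paw Edema Notes on Four Compounds

This account rests on a few compounds, and the source may have more. Where it says the series, first, only, none or still open, it means among the compounds named here.

Measured compounds:
compound 1, `O=c1c2c(Nc3ccccc3)nn(-c3ccc([N+](=O)[O-])cc3)c2nc(Nc2ccccc2)n1-c1ccccc1`: 43.9%
compound 2, `NS(=O)(=O)c1ccc(-n2nc(Nc3ccccc3)c3c(=O)n(-c4ccccc4)c(Nc4ccccc4)nc32)cc1`: 60.2%
compound 3, `O=c1c2c(Nc3ccc(Cl)cc3)nn(-c3ccc([N+](=O)[O-])cc3)c2nc(Nc2ccccc2)n1-c1ccccc1`: 39.6%

All three were read in a functional assay on the whole organism (strain Wistar albino) for inhibition, with Rattus norvegicus as the target, read by paw edema, with a stated time of 1 h, at a dose of 25 mg/kg by the oral route; on this read-out higher numbers stand for more inhibition at the one dose given (going by the name of the read-out) and lower numbers for less inhibition. Compound 1 and compound 2 share a core and differ in one place: sulfamoyl in place of nitro on an aromatic carbon. This gave a number 16.3 percentage points higher from compound 1 to compound 2 (beyond the scatter). Compound 3 is related to compound 1 by a different change, (chloro in place of hydrogen on an aromatic carbon), and the step of a number 4.3 percentage points lower from compound 1 to compound 3 (within the scatter) is within the scatter, so compound 1 and compound 3 are not separated by this assay. Compound 3 stands furthest from compound 2, the gap being beyond the scatter.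

Compound 4, `NS(=O)(=O)c1ccc(-n2nc(Nc3ccc(Cl)cc3)c3c(=O)n(-c4ccccc4)c(Nc4ccccc4)nc32)cc1`, is not yet measured. It differs from compound 3 in one place: sulfamoyl in place of nitro on an aromatic carbon. The place lines for this change and for the change from compound 1 to compound 2 agree word for word, so it is the same change made on the core of compound 3, which carries the chloro group. Because a number 16.3 percentage points higher from compound 1 to compound 2 (beyond the scatter) was measured for the same change, a step of similar size is expected here, namely a number 15.4 percentage points higher from compound 3 to compound 4 (beyond the scatter). Among the measured compounds shown here, with only one prior instance, the range is kept wide. For compound 4 the expected value in this assay is 55%, between 42% and 68%.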

Compound 4, a percentage reported as inhibition, in the whole organism at one dose (the size of the read-out at that dose, not a potency): 69.8%
For compound 4 the middle estimate is 14.8 percentage points below the measured one; the whole stated range lies below it.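

In this assay, sulfamoyl in place of nitro on the core carrying the chloro group gives a number 30.2 percentage points higher from compound 3 to compound 4 (beyond the scatter), so the change points the same way on both cores, and the two steps are not separated from each other: the same change on two cores in this assay, a number 16.3 percentage points higher (beyond the scatter) from compound 1 to compound 2 and a number 30.2 percentage points higher (beyond the scatter) from compound 3 to compound 4, 13.9 percentage points apart, within the scatter of two such steps. The chloro group makes no readable difference on either core, as a number 9.6 percentage points higher from compound 2 to compound 4 (within the scatter) also stays within the scatter: the same change on two cores in this assay, a number 4.3 percentage points lower (within the scatter) from compound 1 to compound 3 and a number 9.6 percentage points higher (within the scatter) from compound 2 to compound 4, 13.9 percentage points apart, within the scatter of two such steps. This supports carrying the change between two cores that differ only by chloro in place of hydrogen, but two instances fix no reliable step size and say nothing about cores that differ more widely.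

The compounds shown leave open whether the higher numbers are particular to sulfamoyl or would also come with a methylsulfonyl group or a carboxylic acid in place of nitro. Also open, going by these compounds, is whether a methoxy group or a fluoro group in place of the chloro would keep the reading, and whether the picture holds at other doses and times.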